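Trading a Phenoxy Arm for a Benzyl Arm

The source may hold more compounds than are shown below. What is called first, only, known or untested is meant among the compounds shown, and "the series" means these compounds.

Of the compounds shown here, three built on one shared core have been tested in a functional assay on MCF7 cells (Homo sapiens) for antiproliferative activity; a higher number here means a weaker inhibitor, a lower number a stronger inhibitor. Compound 1 `COc1ccc(Oc2ccc3cc(NC(=O)c4ccc(OC(C)=O)c(CC=C(C)C)c4)c(=O)oc3c2C)cc1` gives 18200 nM. Compound 2 `COc1ccc(Oc2ccc3cc(NC(=O)c4ccc(O)c(CC=C(C)C)c4)c(=O)oc3c2C)cc1` gives 6510 nM, and compound 3 `COCOc1ccc(Cc2ccc3cc(NC(=O)c4ccc(OC(C)=O)c(CC=C(C)C)c4)c(=O)oc3c2C)cc1` gives 22700 nM. Compound 2 holds the lowest number of the three, with compound 1 nearest and compound 3 furthest, both beyond the scatter. Two single changes connect the measured compounds. The step of a 2.8-fold lower number from compound 1 to compound 2 (0.45 log units; beyond the scatter) came from hydrogen in place of acetyl on an oxygen on an aromatic ring, a modest but real change. The step of a 1.2-fold higher number from compound 1 to compound 3 (0.10 log units; within the scatter) came from 4-(methoxymethoxy)benzyl in place of 4-methoxyphenoxy on an aromatic carbon and stayed within the scatter.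

Compound 4 `CC(C)=CCc1cc(C(=O)Nc2cc3ccc(Cc4ccc(O)cc4)c(C)c3oc2=O)ccc1O` has not yet been measured. Against compound 2 the difference is this: 4-hydroxybenzyl in place of 4-methoxyphenoxy on an aromatic carbon. Within the data shown here, no measured step matches this change exactly. The closest guide is a 1.2-fold higher number from compound 1 to compound 3 (0.10 log units; within the scatter), where a related benzyl group replaced the same 4-methoxyphenoxy and the number barely moved. On that basis little movement is expected. Compound 4 is therefore expected to give 5500 nM, within a range from 1800 nM to 17000 nM. The step this estimate implies, a 1.2-fold lower number from compound 2 to compound 4 (0.07 log units; within the scatter), is expected to stay within the scatter.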

Compound 4, half-maximal inhibitory concentration: 32100 nM
Beside the measured number, compound 4's estimate is 5.8-fold (0.77 log units) below it, and the stated range ends below it.
By their numbers in this assay, from the lowest: compound 2; then compounds 1, 3 and 4 (each within the scatter of the next).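

The 4-hydroxybenzyl arm does not behave as a quiet replacement for 4-methoxyphenoxy at this position, ortho to a methyl group: in this assay the change gives a 4.9-fold higher number from compound 2 to compound 4 (0.69 log units; beyond the scatter) and loses ground against compound 2, which carries a free hydroxyl on the other aromatic ring. The earlier swap at the same position, a 1.2-fold higher number from compound 1 to compound 3 (0.10 log units; within the scatter), involved a different benzyl group on a partner with an acetyl on that oxygen, so the two results together show that replacing this arm does not have one fixed outcome. No measurement given here explains why these two steps differ.

The change to compound 4 alters the link to the ring and the group at the far end of the arm at once, so the compounds shown do not say which of the two carries the loss. A 4-methoxybenzyl group or a 4-hydroxyphenoxy group at this position would separate those two changes, and an acetyl on the hydroxyl of compound 4 would test whether the partner on the other ring matters.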